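A Fourth Variation at the Side-Chain Carbon

The compounds below may be only part of what the source reports. "The series", "measured", "known", "first", "only" and "open" are said of these compounds alone.

Compounds measured so far:
compound 1 `CCCCC(CCCC)C(O/N=C(\C)C(=O)O)c1ccc(OCc2ccc3ccccc3n2)cc1`: 14 nM
compound 2 `C/C(=N\OC(c1ccc(OCc2ccc3ccccc3n2)cc1)C1CCCC1)C(=O)O`: 16 nM
compound 3 `C/C(=N\OC(CC(C)(C)c1ccccc1)c1ccc(OCc2ccc3ccccc3n2)cc1)C(=O)O`: 22 nM

In a functional assay for inhibition of Polyunsaturated fatty acid 5-lipoxygenase (Homo sapiens) (a lower number here means a stronger inhibitor, a higher number a weaker inhibitor), compound 3 gives the highest of the three numbers, though its gaps to compound 2 and to compound 1 both sit within the scatter. Compound 4 `C/C(=N\OC(CCCc1ccc(F)cc1)c1ccc(OCc2ccc3ccccc3n2)cc1)C(=O)O` differs from compound 3 in one place: 2-(4-fluorophenyl)ethyl in place of 1-methyl-1-phenylethyl on a saturated chain carbon, two bonds along the chain from an aromatic carbon and an oxygen. All three measured steps, a 1.1-fold higher number from compound 1 to compound 2 (0.06 log units; within the scatter), a 1.6-fold higher number from compound 1 to compound 3 (0.20 log units; within the scatter) and a 1.4-fold higher number from compound 2 to compound 3 (0.14 log units; within the scatter), exchange the group on this same chain carbon, and none of them moves the number beyond the scatter. A fourth exchange at the same place is therefore expected to leave the number roughly where it stands. Compound 4 is estimated at 20 nM, with a range from 8 nM to 50 nM. The expected step from compound 3 is a 1.1-fold lower number from compound 3 to compound 4 (0.04 log units; within the scatter), not beyond the scatter.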

Compound 4, half-maximal inhibitory concentration: 9 nM
Compound 4: middle estimate off by 2.2-fold (0.35 log units), on the high side; the range from low to high includes it.
By their numbers in this assay, from the lowest: compounds 4, 1, 2 and 3 (each within the scatter of the next, the first and the last beyond it).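

In this assay, this chain carbon now shows a change beyond the scatter, a 2.4-fold lower number from compound 3 to compound 4 (0.39 log units; beyond the scatter), when 2-(4-fluorophenyl)ethyl replaces 1-methyl-1-phenylethyl at an unchanged heavy-atom count. The other two comparisons stay within the scatter, a 1.8-fold lower number from compound 2 to compound 4 (0.25 log units; within the scatter) and a 1.6-fold lower number from compound 1 to compound 4 (0.19 log units; within the scatter), so only compound 3 and compound 4 are separated. No available evidence bears on the cause of this step.

The compounds shown leave open how much of the step belongs to the fluorine and how much to the unbranched chain. A 3-phenylpropyl group on this carbon would separate the two.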